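This account rests on a few compounds, and the source may have more. Where it says the series, first, only, none or still open, it means among the compounds named here.

Measured so far in a functional assay on HeLa cells (Homo sapiens) for cytotoxicity, read by MTT assay, with a stated time of 72 h; on this read-out higher numbers stand for weaker inhibition and lower numbers for stronger inhibition:
compound 1 `Cc1nnc(SCc2coc3ccc(Cl)cc3c2=O)o1`: 3200 nM
compound 2 `Cc1nnc(SCc2coc3ccccc3c2=O)s1`: 2300 nM
compound 3 `Cc1nnc(SCc2coc3ccccc3c2=O)o1`: 1400 nM

Compound 3 gives the lowest of the three numbers. Its distance from compound 1 is real, a 2.3-fold lower number from compound 1 to compound 3 (0.36 log units; beyond the scatter), whereas its distance from compound 2, a 1.6-fold lower number from compound 2 to compound 3 (0.22 log units; within the scatter), stays within the scatter, so compound 2 and compound 3 cannot be told apart on these data.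

Compound 4 `Nc1nnc(SCc2coc3ccccc3c2=O)s1` is the next compound to be run. It differs from compound 3 in one place: 5-amino-1,3,4-thiadiazol-2-yl in place of 5-methyl-1,3,4-oxadiazol-2-yl on a sulfur. Going by the values given here, of the measured steps only one bears on this change, the exchange of the ring on the sulfur seen in a 1.6-fold lower number from compound 2 to compound 3 (0.22 log units; within the scatter), which was too small to count. For the amino group that enters where a methyl stood, nothing has been measured at all, so that part of the change carries no evidence in either direction. The expected step of a 1.4-fold higher number from compound 3 to compound 4 (0.15 log units; within the scatter) is therefore small, with no direction that can be read from the numbers in hand, and compound 4 is estimated at 2000 nM with a range from 900 nM to 4500 nM in this assay.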

Compound 4, half-maximal inhibitory concentration: > 25000 nM
Compound 4 was reported as a limit; the forecaster's own chance of this, stated with the estimate: 3%; at least 12-fold (1.09 log units) between middle value and limit.
By their numbers in this assay, from the lowest: compounds 3, 2 and 1 (each within the scatter of the next, the first and the last beyond it). At a limit, above all of these: compound 4.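

Compound 4 is reported in this assay only as a limit, not as a number: the limit of > 25000 nM in this assay, at which 1 of the 4 values shown sits. Going by these compounds alone, the earlier compounds showed only that the ring on the sulfur could be exchanged without a step beyond the scatter, a 1.6-fold lower number from compound 2 to compound 3 (0.22 log units; within the scatter), whereas with the same ring kept, amino in place of methyl on an aromatic carbon gives an at least 10-fold higher number from compound 2 to compound 4 (1.03 log units; beyond the scatter). The full exchange at this position, an at least 17-fold higher number from compound 3 to compound 4 (1.25 log units; beyond the scatter), is likewise large, so among these four compounds the large loss goes with the amino group that replaces methyl, not with the exchange of the ring itself.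

As far as these compounds go, the true size of both large steps stays open: they rest on a limit. Open too, from the compounds shown here alone, is whether 5-amino-1,3,4-oxadiazol-2-yl would behave as 5-amino-1,3,4-thiadiazol-2-yl does, and whether an acetamide, a dimethylamino group or a hydroxyl group in place of the amino would bring back numbers like those seen with methyl.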